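Moving the ring nitrogen in a thioether-linked coumarin

The source may hold more compounds than are shown below. What is called first, only, known or untested is meant among the compounds shown, and "the series" means these compounds.

Compound 1 `Cc1cc(=O)oc2cc(Sc3cccc(Cl)[n+]3[O-])ccc12` gives > 31200 nM in a functional assay on KB cells (Homo sapiens) for antiproliferative activity, read by sulforhodamine B assay, with a stated time of 72 h (a higher number here means a weaker inhibitor of growth, a lower number a stronger inhibitor of growth), which is a limit of the assay.
Compound 2 `Cc1cc(=O)oc2cc(SC3CCOC3=O)ccc12` gives > 36100 nM in this assay, also a limit.
Compound 3 `Cc1cc(=O)oc2cc(SCc3ccccn3)ccc12` gives > 35200 nM in this assay, again a limit.

These three compounds share a core and differ only in the group carried on the sulfur. None of them gives a number in this assay. For compound 3 the entry is a limit (the limit of > 35200 nM in this assay, at which 1 of the 3 values shown sits). For compound 1 the entry is likewise a limit (the limit of > 31200 nM in this assay, at which 1 of the 3 values shown sits). For compound 2 the entry is a limit as well (the limit of > 36100 nM in this assay, at which 1 of the 3 values shown sits). Among the compounds with values here, no compound here has a measured number, so no step between measured compounds can be read, and no compound can be called stronger or weaker than another.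

Compound 4 `Cc1cc(=O)oc2cc(SCc3ccncc3)ccc12` is not yet measured. It differs from compound 3 in one place: pyridin-4-yl in place of pyridin-2-yl on a saturated chain carbon bound to a sulfur. The two have the same atoms, joined differently.

With every measured value sitting at a limit, there is no basis for expecting a step of any size in either direction. The step from compound 3 to compound 4 is expected to be a step that the limit leaves unreadable from compound 3 to compound 4, no more than the usual scatter. Compound 4 is therefore expected to give about 40000 nM, in a range from 15000 nM to 100000 nM, and most likely the assay will again report only a limit.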

Compound 4, concentration for 50% growth inhibition: > 35200 nM
Compound 4: a limit, no number; the forecaster's own chance of this, stated with the estimate: 85%; the middle value is on the limit's open side.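

No step can be read between compound 3 and compound 4, because neither entry is a number and both stand at the same limit: the limit of > 35200 nM in this assay, at which 2 of the 4 values shown sit.

The compounds shown leave open whether pyridin-4-yl in place of pyridin-2-yl changes growth inhibition at all, and which group on the sulfur would give a measured number in this assay.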